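The source may report more compounds than this note shows. Statements on the series, on what has been measured and on what is new or still open speak of the compounds shown alone.

Measured in a functional assay on MCF7 cells (Homo sapiens) for cytotoxicity, read by MTT assay, with a stated time of 4 days; a lower number here means a stronger inhibitor, a higher number a weaker inhibitor:
compound 1 `C=C1C(=O)[C@]23C[C@@]1(O)CC[C@H]2c1ccc(OS(=O)(=O)c2ccc(C)cc2)c(C)c1[C@@H]3Cn1cc(-c2ccc(C)cc2)nn1`: 320 nM
compound 2 `C=C1C(=O)[C@]23C[C@@]1(O)CC[C@H]2c1ccc(O)c(C)c1[C@@H]3Cn1cc(-c2ccc(OC)cc2)nn1`: 1710 nM

Compound 2 stands at the highest number of the two; the gap to its nearest neighbour, compound 1, lies beyond the scatter. Among the measured compounds shown here, compound 1 and compound 2 differ in two places at once, so their values show only that the compound carrying the sulfonyl ester gives the lower number, without separating the two changes.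

Compound 3 `C=C1C(=O)[C@]23C[C@@]1(O)CC[C@H]2c1ccc(OS(=O)(=O)c2ccc(C)cc2)c(C)c1[C@@H]3Cn1cc(-c2ccc(OC)cc2)nn1` is compound 2 with (4-methylphenyl)sulfonyl in place of hydrogen on an oxygen on an aromatic ring. For the measured compounds named here, no measured pair isolates this change. Compound 1, which carries the same group, gives 320 nM; compound 2 gives 1710 nM. For compound 3 a downward step in this assay of about a 3.1-fold lower number from compound 2 to compound 3 (0.49 log units; beyond the scatter) is expected, with the second difference between compound 1 and compound 2 leaving the size uncertain. The estimate for compound 3 is 550 nM, within 180 nM to 1700 nM.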

Compound 3, half-maximal inhibitory concentration: 310 nM
Compound 3: the middle estimate sits 1.8-fold (0.25 log units) above what was measured; the measured number falls inside the stated range.
By their numbers in this assay, from the lowest: compounds 3 and 1 (each within the scatter of the next); then compound 2.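

In this assay, the change from hydroxy to ((4-methylphenyl)sulfonyl)oxy on the aromatic ring now stands alone, giving a 5.5-fold lower number from compound 2 to compound 3 (0.74 log units; beyond the scatter) with the rest of the molecule unchanged. The second pair, with a 1.0-fold lower number from compound 1 to compound 3 (0.01 log units; within the scatter) for methoxy in place of methyl on an aromatic carbon, shows no separable effect of that exchange in the presence of the sulfonyl ester, so the gap between compound 1 and compound 2 follows the sulfonyl ester in these compounds. The data shown offer no measurement that explains either result.

From the compounds shown here alone, whether the step needs the (4-methylphenyl)sulfonyl group as a whole remains open, and a methanesulfonyl or acetyl group on the same oxygen would test this. Going by these compounds, whether methoxy and methyl also match when the hydroxy group is free also remains open.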